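The source may report more compounds than this note shows. Statements on the series, on what has been measured and on what is new or still open speak of the compounds shown alone.

Compound 1, `CCC(CC)c1ccc(NC(=O)c2c(-c3c(Cl)cccc3Cl)noc2C)cc1`: > 10000 nM
Compound 2, `CCN(CC)c1ccc(NC(=O)c2c(-c3c(Cl)cccc3Cl)noc2CCC2OCCCO2)c(C)c1`: 9 nM

Compound 1 reaches only a limit of the assay: in an assay on isolated protein for binding affinity to growth hormone secretagogue receptor type 1 (Homo sapiens) (a lower number here means a stronger inhibitor, a higher number a weaker inhibitor), compound 1 gives > 10000 nM, a limit and not a number. In this assay compound 2 gives 9 nM. Going by the values given here, compound 2 therefore stands as the holder of the only numerical value shown, the other entry being (the limit of > 10000 nM in this assay, at which 1 of the 2 values shown sits). Compounds 1 and 2 differ in several places at once, so their two values show only that one is a limit and the other a number.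

Compound 3, `CCN(CC)c1ccc(NC(=O)c2c(-c3c(Cl)cccc3Cl)noc2C)c(C)c1`, is made from compound 2 by a single change: a hydrogen atom in place of a group of 7 heavy atoms (5 carbon, 2 oxygen; one six-membered non-aromatic ring with 2 hetero atoms), on a saturated chain carbon bound to an aromatic carbon. Among the compounds with values here, no step between two measured compounds carries this change, so the expectation rests on the structures alone. The removal of a group of this size is expected to cost affinity in this assay by a moderate amount, beyond the usual scatter but not large. Compound 3 is expected to give about 40 nM in this assay, within the range 8 nM to 300 nM. The step this estimate implies, a 4.4-fold higher number from compound 2 to compound 3 (0.65 log units; beyond the scatter), is expected to be a loss.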

Compound 3, half-maximal inhibitory concentration: 37 nM
Beside the measured number, compound 3's estimate is 1.1-fold (0.03 log units) above it, within the range that was stated.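

In this assay, going by these compounds alone, replacing the group with one six-membered non-aromatic ring with 2 hetero atoms by hydrogen, on a saturated chain carbon bound to an aromatic carbon, gives a 4.1-fold higher number from compound 2 to compound 3 (0.61 log units; beyond the scatter), the first comparison in this set that isolates a single place. The change is a modest loss and does not abolish the read-out: compound 3 still gives a number, 37 nM, so the affinity seen in this assay does not rest on this group alone. Nothing measured here accounts for the size of this step.

As far as these compounds go, it remains open whether the ring, its two oxygen atoms or simply the chain carrying them matters for the step, and how a plain propyl chain, a chain ending in an amine or one ending in a carboxylic acid would compare at this place. Compound 1 stays at a limit of the assay, > 10000 nM, and it differs from the other compounds in more than one place, so what separates it from them also remains unresolved.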